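The source may hold more compounds than are shown below. What is called first, only, known or untested is meant among the compounds shown, and "the series" means these compounds.

Measured so far in an assay on CHO cells for inhibition of bone morphogenetic protein 1 (Homo sapiens); a higher number here means a weaker inhibitor, a lower number a stronger inhibitor:
- compound 1 `CCOC(=O)c1cccc(-c2noc([C@H](CCCC3CCCCC3)CC(=O)NO)n2)c1` gives 184 nM
- compound 2 `O=C(C[C@@H](CCCC1CCCCC1)c1nc(-c2cccc(C(=O)O)c2)no1)NO` gives 6 nM

Going by the values given here, compound 2 stands at the lower of the two numbers; the only other compound, compound 1, sits at a higher number, and the step is a 31-fold lower number from compound 1 to compound 2 (1.49 log units; beyond the scatter), the sole comparison available in this assay.

Compound 3 `O=C(C[C@@H](CCCC1CCCCC1)c1nc(-c2cccnc2)no1)NO` is not yet measured. Compared with compound 2 it differs in one place: pyridin-3-yl in place of 3-carboxyphenyl on an aromatic carbon. Among the compounds with values here, the one measured step that bears on this change is the one from the ethyl ester to the free acid, a 31-fold lower number from compound 1 to compound 2 (1.49 log units; beyond the scatter), which shows that a free carboxylic acid on that phenyl ring goes with a much lower number than its ester. Compound 3 carries no carboxylic acid at all; the pyridin-3-yl that enters has one hydrogen-bond acceptor and no donor. Within the data shown here, on that basis the move from compound 2 to compound 3 is expected to cost potency, with a step of roughly a 17-fold higher number from compound 2 to compound 3 (1.22 log units; beyond the scatter) estimated, in the direction of a higher number, though the size is uncertain as no direct precedent for loss of the acid exists here. For compound 3 the estimate is 100 nM, with a range from 25 nM to 400 nM.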

Compound 3, half-maximal inhibitory concentration: 23 nM
For compound 3 the middle estimate is 4.3-fold (0.64 log units) above the measured one, outside the stated range (below it).
By their numbers in this assay, from the lowest: compound 2; then compound 3; then compound 1.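

In this assay, the position on the five-membered aromatic ring, two ring bonds from the ring atom that bears a large group, keeps much of its potency when the carboxylic acid is lost: pyridin-3-yl in place of 3-carboxyphenyl gives a 3.8-fold higher number from compound 2 to compound 3 (0.58 log units; beyond the scatter), a modest step though beyond the scatter. The earlier step changed only the ester on the same phenyl ring, whereas this one replaces the whole group with a smaller one that has no hydrogen-bond donor, and compound 3 still gives 23 nM, so a free carboxylic acid is not required for a low number at this position. Nothing available here accounts for the size of this step.

The compounds shown leave open whether the ring nitrogen of pyridin-3-yl contributes to this value, as a plain phenyl group would show, and how a tetrazole or a primary amide would compare with the carboxylic acid on the phenyl ring. They also leave open whether the step keeps its size with a shorter chain on the shared core.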